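Swapping 3-fluorophenyl for 4-methoxyphenyl on a shared core

The source may hold more compounds than are shown below. What is called first, only, known or untested is meant among the compounds shown, and "the series" means these compounds.

Of the compounds shown here, three sharing one core have been measured in a functional assay on MCF7 cells (Homo sapiens) for antiproliferative activity, read by sulforhodamine B assay, with a stated time of 48 h; on this read-out lower numbers stand for stronger inhibition and higher numbers for weaker inhibition. Compound 1 `Cc1ccccc1OS(=O)(=O)c1ccc(N2CCN(C)C2=O)cc1` gives 5600 nM. Compound 2 `Cc1ccc(OS(=O)(=O)c2ccc(N3CCN(C)C3=O)cc2)c(C)c1` gives 2500 nM, which is a 2.2-fold lower number from compound 1 to compound 2 (0.35 log units; beyond the scatter). Compound 3 `CN1CCN(c2ccc(S(=O)(=O)Oc3cccc(F)c3)cc2)C1=O` gives > 100000 nM, which is a limit of the assay and not a number.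

Compound 4 `COc1ccc(OS(=O)(=O)c2ccc(N3CCN(C)C3=O)cc2)cc1` keeps the shared core and carries 4-methoxyphenyl in place of 3-fluorophenyl on an oxygen. Among the measured compounds shown here, no measured step makes this exact exchange. The closest evidence comes from the two steps that change the group on the same oxygen, an at least 17-fold higher number from compound 1 to compound 3 (1.25 log units; beyond the scatter) and an at least 40-fold higher number from compound 2 to compound 3 (1.60 log units; beyond the scatter). Both are large, whereas the added methyl on an aromatic carbon gave only a modest step. Among these three compounds, then, the group on this oxygen moves the read-out widely, and only the 3-fluorophenyl compound reaches the limit.

A large move to a lower number is therefore expected, resting on compound 1 at 5600 nM and compound 2 at 2500 nM, although neither carries a methoxy group. The expected change is an at least 12-fold lower number from compound 3 to compound 4 (1.09 log units; beyond the scatter). For compound 4 the estimate is 8000 nM, with an expected range of 1200 nM to 60000 nM.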

Compound 4, half-maximal inhibitory concentration: 95000 nM
Estimate against measurement, compound 4: 12-fold (1.07 log units) below, outside the stated range (above it).
By their numbers in this assay, from the lowest: compound 2; then compound 1; then compound 4. At a limit, above all of these: compound 3.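

In this assay, 4-methoxyphenyl on this oxygen sits far from both methyl-bearing groups, with a 17-fold higher number from compound 1 to compound 4 (1.23 log units; beyond the scatter) and a 38-fold higher number from compound 2 to compound 4 (1.58 log units; beyond the scatter), and both steps are large. Weak inhibition here is therefore not confined to the 3-fluorophenyl compound: among these four compounds, the two with 2-methylphenyl and 2,4-dimethylphenyl give the lowest numbers, and neither of the two compounds without a methyl on this ring comes near them. Compound 3 stands at a limit of the assay and has no exact number. The exchange itself shows only an at least 1.0-fold lower number from compound 3 to compound 4 (0.02 log units; that floor lies within the scatter) and its full size remains unsized: the limit of > 100000 nM in this assay, at which 1 of the 4 values shown sits.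

The compounds shown leave open whether the high number of compound 4 follows from the methoxy group itself, since no compound with a 4-methylphenyl or an unsubstituted phenyl on this oxygen stands beside it. They also leave open how the read-out would respond to an amine or a carboxylic acid on this ring, and whether a methyl group would keep its lower numbers when paired with fluorine.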